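This account rests on a few compounds, and the source may have more. Where it says the series, first, only, none or still open, it means among the compounds named here.

Compound 1 `Cn1cc(C2=C(c3n[nH]c4ncccc34)C(=O)NC2=O)c2ccccc21` is the starting point of this account. In a functional assay on K562 cells (Homo sapiens) for antiproliferative activity, read by MTT assay, with a stated time of 48 h (on this read-out lower numbers stand for stronger inhibition and higher numbers for weaker inhibition), compound 1 gives only a limit, > 100000 nM, so its place on the scale is not a number but the edge of what was measured. Compound 2 `Cn1cc(C2=C(c3n[nH]c4ncccc34)C(=O)N(c3cccc4ccccc34)C2=O)c2ccccc21` carries naphthalen-1-yl in place of hydrogen on an amide-type nitrogen in a ring. In this assay compound 2 likewise gives a limit, > 100000 nM. The step from compound 1 to compound 2 is a step that the two limits leave unreadable from compound 1 to compound 2, a step the two limits leave unreadable, because both compounds sit at the limit of > 100000 nM in this assay, at which 2 of the 3 values shown sit. Among the compounds with values here, compound 3 `Cn1cc(C2=C(c3nn(CCCn4ccnc4)c4ncccc34)C(=O)N(c3ccccc3)C2=O)c2ccccc21` differs from compound 1 in two places at once, a phenyl on the amide-type nitrogen and a propyl-linked imidazole on the aromatic nitrogen; in this assay compound 3 gives 5510 nM, the one readable number in the set.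

Compound 4 `Cn1cc(C2=C(c3nn(CCCn4cccc4)c4ncccc34)C(=O)NC2=O)c2ccccc21` is the compound not yet measured. It differs from compound 1 by 3-(1H-pyrrol-1-yl)propyl in place of hydrogen on an aromatic nitrogen. Within the data shown here, no measured step bears directly on this change; the step from compound 1 to compound 2 is unreadable, and compound 3 shows only that a doubly changed compound reaches a measurable value. Compound 4 is therefore expected to move, if at all, toward a measurable value, with a step from compound 1 of an at least 3.3-fold lower number from compound 1 to compound 4 (0.52 log units; beyond the scatter). The estimate for compound 4 in this assay is 30000 nM, within a range from 5000 nM to 200000 nM.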

Compound 4, half-maximal inhibitory concentration: 21600 nM
For compound 4 the middle estimate is 1.4-fold (0.14 log units) above the measured one; low and high end bracket the measured number.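

In this assay, within the data shown here, the single change of 3-(1H-pyrrol-1-yl)propyl in place of hydrogen on the aromatic nitrogen gives an at least 4.6-fold lower number from compound 1 to compound 4 (0.66 log units; beyond the scatter) and so shows, for the first time in this set, what this position does without a second change elsewhere in the molecule. Compound 4 keeps the hydrogen on the amide-type nitrogen, so a readable number here does not depend on any group at that nitrogen. The size of the step has only a lower bound and its full extent cannot be read, since compound 1 stands at a limit of the assay and not at a number: the limit of > 100000 nM in this assay, at which 2 of the 4 values shown sit.

The compounds shown leave open whether the gain belongs to the pyrrole ring or to the propyl chain alone, a question that a plain propyl group, a shorter ethyl chain, a longer butyl chain or a terminal amine on the chain would address at this same nitrogen. They also leave open how a propyl-linked imidazole would behave on the core of compound 1 with the amide hydrogen kept, and whether a phenyl on the amide-type nitrogen adds anything to the pyrrole-bearing chain of compound 4.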